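Amide variation on the shared core

The compounds below may be only part of what the source reports. "The series", "measured", "known", "first", "only" and "open" are said of these compounds alone.

Compound 1 `Cc1cc(-c2c(CCc3ccccc3)c3cc(OCC(=O)NC(C)(C)c4ccccc4)ccc3[nH]c2=O)on1` gives 12 nM in an assay on CHO-K1 cells for displacement of a labelled ligand from adenosine receptor A1 (Homo sapiens), with a stated time of 2 h; a higher number here means a weaker inhibitor, a lower number a stronger inhibitor. Compound 2 `CS(=O)(=O)c1c(CCc2ccccc2)c2cc(OCC(=O)Nc3ccccc3)ccc2[nH]c1=O` gives 1330 nM in this assay, the highest of the two numbers, with compound 1 sitting far lower, beyond the scatter. Compound 3 `Cn1c(=O)c(S(C)(=O)=O)c(CCc2ccccc2)c2cc(OCC(=O)NCc3ccc(Cl)c(Cl)c3)ccc21` returns only a limit in this assay, > 10000 nM; it sits at the limit of > 10000 nM in this assay, at which 1 of the 3 values shown sits. Compound 4 `CN(Cc1ccc(Cl)c(Cl)c1)C(=O)COc1ccc2[nH]c(=O)c(S(C)(=O)=O)c(CCc3ccccc3)c2c1` is not yet measured. It differs from compound 2 in one place: (3,4-dichlorobenzyl)(methyl)amino in place of anilino on a carbonyl carbon. Going by the values given here, no measured pair isolates this change, so its size is open; compound 3 carries the dichlorobenzyl group on a methylated core and gives no number to lean on. The expected step is a 1.9-fold higher number from compound 2 to compound 4 (0.27 log units; within the scatter), weakening and of modest size. Compound 4 is estimated at 2500 nM, within 600 nM to 10000 nM.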

Compound 4, inhibition constant: 602 nM
Compound 4: middle estimate off by 4.2-fold (0.62 log units), on the high side; the measured number falls inside the stated range.
By their numbers in this assay, from the lowest: compound 1; then compound 4; then compound 2. At a limit, above all of these: compound 3.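

In this assay the carbonyl carbon carrying the saturated chain accepts a larger amine part, with the step to (3,4-dichlorobenzyl)(methyl)amino reading (a 2.2-fold lower number from compound 2 to compound 4 (0.34 log units; beyond the scatter)). Going by these compounds alone, this is the first one-place step, and it shows that the hydrogen-bond donor counted on anilino is not needed to keep a measurable number here. Nothing measured accounts for the size of this step.

The methyl group and the dichlorobenzyl group enter together, so their separate shares stay unresolved. Open too, from the compounds shown here alone, is how a plain benzylamino group or a morpholine amide would read at this position.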